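Ethyl to Benzyl on a Chlorinated Amidine Core

A few compounds are considered here, and "the series" means these few. Any claim that something is new, unique, unknown or untested is made for them only; others in the source may bear on it.

Within the data shown here, compound 1 `CCNC1=Nc2ccc(Cl)cc2C(C)(C)C1` gives 89.7% in a functional assay on MDA-MB-231 cells (Homo sapiens) for cytotoxicity, read by MTT assay, with a stated time of 72 h, tested at 1 uM, in the absence of a further agent (on this read-out higher numbers stand for a weaker effect at the one concentration tested and lower numbers for a stronger effect), the highest of the two numbers known. Among the measured compounds shown here, compound 2 `CN(C)CCNC1=Nc2ccc(Cl)cc2C(C)(C)C1` gives 66.9%, and the only measured step is a number 22.8 percentage points lower from compound 1 to compound 2 (beyond the scatter). Compound 3 `CC1(C)CC(NCc2ccccc2)=Nc2ccc(Cl)cc21` differs from compound 1 by phenyl in place of methyl on a saturated chain carbon bound to an amine nitrogen. For the measured compounds named here, no measured step bears directly on this change; the one known step concerns a dimethylamino group at another place on the chain, so it offers no guide to size or direction. Compound 3 is therefore expected to give 80%, within 55% to 100%. The estimated step of a number 9.7 percentage points lower from compound 1 to compound 3 (within the scatter) is expected to stay close to the scatter.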

Compound 3, a percentage reported as activity, at one concentration (the size of the read-out at that concentration, not a potency): 88.8%
Beside the measured number, compound 3's estimate is 8.8 percentage points below it, within the range that was stated.
By their numbers in this assay, from the lowest: compound 2; then compounds 3 and 1 (each within the scatter of the next).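

In this assay the step of a number 0.9 percentage points lower from compound 1 to compound 3 (within the scatter) shows that, at this place on the chain, phenyl in place of methyl leaves the read-out unchanged within the scatter. Phenyl in place of (dimethylamino)methyl at the same place gives a number 21.9 percentage points higher from compound 2 to compound 3 (beyond the scatter) and so marks compound 2 as the one that stands apart from the other two. No evidence is at hand to explain either step.

What the compounds shown leave open is whether a pyridine ring or a carboxylic acid on this chain would stay with compound 1 and compound 3 or move toward compound 2. They also leave open whether a longer chain ending in an amine would do so.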